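The source may report more compounds than this note shows. Statements on the series, on what has been measured and on what is new or still open speak of the compounds shown alone.

In a physicochemical assay for solubility, using the shake flask method, in phosphate buffer, measured as kinetic solubility, with a stated time of 20 h, at pH 6.5 (on this read-out higher numbers stand for higher solubility and lower numbers for lower solubility), three compounds that share one core have been measured. Compound 1 `FC(F)(F)Oc1ccc(-c2nc3cnc(Nc4ccccn4)cc3[nH]2)cc1` gives < 5000 nM, which is a limit and not a number. Compound 2 `COc1cccnc1Nc1cc2[nH]c(-c3cccc(C(F)(F)F)c3)nc2cn1` gives < 5000 nM, which is also a limit. Compound 3 `COc1ccnc(Nc2cc3[nH]c(-c4cccc(C(F)(F)F)c4)nc3cn2)c1` gives < 5000 nM, again a limit. The evidence so far is thus (the limit of < 5000 nM in this assay, at which 3 of the 3 values shown sit), and compound 2 has no exact number.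

Compound 4 `COc1ccc(Nc2cc3[nH]c(-c4cccc(C(F)(F)F)c4)nc3cn2)nc1` has not yet been measured. It carries 5-methoxypyridin-2-yl in place of 3-methoxypyridin-2-yl on a nitrogen on an aromatic ring, (5-methoxypyridin-2-yl in place of 3-methoxypyridin-2-yl on a nitrogen on an aromatic ring). The two have the same atoms, joined differently. The closest measured comparison is a step that the two limits leave unreadable from compound 2 to compound 3, with 4-methoxypyridin-2-yl in place of 3-methoxypyridin-2-yl. That comparison gives no size to carry over, so no change beyond the usual scatter is expected in this assay. The estimated change is a step that the limit leaves unreadable from compound 2 to compound 4. Compound 4 is expected to give about 3000 nM, with an estimated range from 1000 nM to 5000 nM, though another limit is the likelier report.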

Compound 4, solubility: < 5000 nM
Compound 4: no number, only a limit; the forecaster's own chance of this, stated with the estimate: 85%; the middle value does not contradict the limit.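

In this assay compound 4 gives < 5000 nM, which is a limit and not a number. Among these compounds, compound 2 and compound 3 also have only limits, so no step from either to compound 4 can be read. Still open, from the compounds shown here alone, is whether 3-methoxypyridin-2-yl, 4-methoxypyridin-2-yl and 5-methoxypyridin-2-yl differ at all in this assay.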